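The source may hold more compounds than are shown below. What is called first, only, known or untested is meant among the compounds shown, and "the series" means these compounds.

Compound 1, with structure `C=CCc1cc(C(C)=O)c(O)cc1OCC#N`, gives the lowest number of the three compounds measured in an assay on isolated protein for inhibition of leukotriene B4 receptor 1 (Homo sapiens), tested at 10 uM; on this read-out lower numbers stand for less inhibition and higher numbers for more inhibition at the one concentration tested (going by the name of the read-out); in that assay compound 1 gives 20%. Compound 2, `CCc1cc(C(C)=O)c(O)cc1OCCCC(C)(C)C#N`, gives 85%, and compound 3, `CCc1cc(C(C)=O)c(O)cc1OCCCCCCC(C)(C)C#N`, gives 65%, so compound 1 sits well below both, beyond the scatter in each case. Among the compounds with values here, the only single-site step among the measured compounds is a number 20 percentage points lower from compound 2 to compound 3 (beyond the scatter); it keeps the nitrile and lengthens the chain between it and the aromatic oxygen.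

Compound 4, `C=CCc1cc(C(C)=O)c(O)cc1OCCCCCCC`, has not been measured in this assay. It differs from compound 1 by hexyl in place of cyano on a saturated chain carbon bound to an oxygen on an aromatic ring. Within the data shown here, no measured pair isolates this change: the one step that exists removes nothing and adds chain length while the nitrile stays, and compounds 2 and 3 differ from compound 1 at more than one site, so their higher values cannot be read as the effect of a longer chain alone. Among the measured compounds shown here, the exchange of the nitrile for a hexyl chain has no close precedent here, and the expectation for compound 4 must therefore be wide. A modest rise is considered most likely, and the estimated step is a number 20 percentage points higher from compound 1 to compound 4 (beyond the scatter). Compound 4 is expected to give about 40% in this assay, plausibly between 15% and 70%.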

Compound 4, a percentage reported as inhibition, at one concentration (the size of the read-out at that concentration, not a potency): 31%
For compound 4 the middle estimate is 9 percentage points above the measured one; measured number inside the range.
By their numbers in this assay, from the lowest: compound 1; then compound 4; then compound 3; then compound 2.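

In this assay, the change gives a number 11 percentage points higher from compound 1 to compound 4 (beyond the scatter), the first step shown in which the cyano group leaves rather than stays. On a saturated chain carbon bound to an oxygen on an aromatic ring, the nitrile is therefore not required for inhibition to be seen: compound 4 has no nitrile and no hydrogen-bond acceptor in the entering hexyl, yet it gives 31%. The step is real but modest for a change that replaces a group of 2 heavy atoms with one of 6, and nothing measured here explains why the number moves as it does.

This single pair cannot separate the loss of the cyano group from the gain in chain length, and compound 2 and compound 3 differ from compound 4 in more than one place, so their values do not settle the question. Going by these compounds, it also remains open how a longer chain, or a chain ending in a carboxylic acid or an amine, would read in this place on the core of compound 1.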